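Silyl ether to formyl ester on the shared core

The source may report more compounds than this note shows. Statements on the series, on what has been measured and on what is new or still open speak of the compounds shown alone.

Compound 1 `C=C1[C@@H](OC(C)=O)C[C@@H]2[C@](C)(CO[Si](C)(C)C(C)(C)C)[C@H](OC(C)=O)CC[C@@]2(C)[C@@H]1C[C@@H](Nc1ccccc1)C1=CCOC1=O` is, in a functional assay on HT-29 cells (Homo sapiens) for cytotoxicity, read by sulforhodamine B assay (a lower number here means a stronger inhibitor, a higher number a weaker inhibitor), the compound with the lowest number of the three measured, giving 4050 nM. Compound 3 `C=C1[C@@H](OC(C)=O)C[C@@H]2[C@](C)(CO[Si](C)(C)C(C)(C)C)[C@H](OC(C)=O)CC[C@@]2(C)[C@@H]1C[C@@H](Nc1cccc2ccccc12)C1=CCOC1=O` gives 15000 nM and the step of a 3.7-fold higher number from compound 1 to compound 3 (0.57 log units; beyond the scatter) concerns only the group on the amine nitrogen. Compound 2 `C=C1[C@@H](OC(C)=O)C[C@@H]2[C@](C)(COC=O)[C@H](OC(C)=O)CC[C@@]2(C)[C@@H]1C[C@@H](Nc1ccccc1C(=O)O)C1=CCOC1=O` gives 28700 nM but differs from compound 1 in two places at once. Compound 4 `C=C1[C@@H](OC(C)=O)C[C@@H]2[C@](C)(COC=O)[C@H](OC(C)=O)CC[C@@]2(C)[C@@H]1C[C@@H](Nc1ccccc1)C1=CCOC1=O` differs from compound 1 by a group of 2 heavy atoms (1 carbon, 1 oxygen; no ring) in place of a group of 7 heavy atoms (6 carbon, 1 silicon; no ring), on an oxygen on a saturated carbon. Within the data shown here, no measured pair isolates this change, so the direction is uncertain; compound 2, the only other compound carrying the formyl group, sits at the weak end, which tilts the expectation toward a higher number. For compound 4 a step of a 2.5-fold higher number from compound 1 to compound 4 (0.39 log units; beyond the scatter) is expected, giving an estimated 10000 nM with a range of 3000 nM to 40000 nM.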

Compound 4, half-maximal inhibitory concentration: 28800 nM
Compound 4: the middle estimate sits 2.9-fold (0.46 log units) below what was measured; low and high end bracket the measured number.
By their numbers in this assay, from the lowest: compound 1; then compounds 3, 2 and 4 (each within the scatter of the next).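

In this assay, among these compounds, the step of a 7.1-fold higher number from compound 1 to compound 4 (0.85 log units; beyond the scatter) is the first direct reading of formyl in place of the group of 7 heavy atoms on this oxygen, and it is beyond the scatter. With formyl present, the step of a 1.0-fold higher number from compound 2 to compound 4 (0.00 log units; within the scatter) shows no separation for hydrogen in place of carboxy on the aromatic carbon. The weak number of compound 2 is therefore matched with formyl and no carboxy present.

Going by these compounds, a free hydroxyl or an acetyl group on this oxygen remains open, as does carboxy on the aromatic carbon with the group of 7 heavy atoms retained. No supporting data explain the step.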